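The source may hold more compounds than are shown below. What is called first, only, known or untested is meant among the compounds shown, and "the series" means these compounds.

Compound 1 `C[C@H]1CO[C@@H](c2nc(-c3ccc(C(=O)Nc4cc(C(F)(F)F)ccn4)cc3F)c3c(N)nccn23)CN1C(=O)C1CC1`, in an ADME assay on the whole organism for pharmacokinetics, with Rattus norvegicus as the target, at a dose of 10 mg/kg by the oral route (on this read-out higher numbers stand for higher oral bioavailability and lower numbers for lower oral bioavailability), compound 1 gives 40%.
Compound 2 `COCC(=O)N1CCO[C@@H](c2nc(-c3ccc(C(=O)Nc4cc(C(F)(F)F)ccn4)cc3F)c3c(N)nccn23)C1`, in this assay compound 2 gives 42%.

Among the two measured compounds, compound 2 gives the higher of the two numbers in this assay, but its nearest neighbour is compound 1, and the gap between them, a number 2 percentage points higher from compound 1 to compound 2 (within the scatter), lies within the scatter, so the two cannot be told apart on this read-out.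

Compound 3 `CC(C)C(=O)N1CCO[C@@H](c2nc(-c3ccc(C(=O)Nc4cc(C(F)(F)F)ccn4)cc3F)c3c(N)nccn23)C1` has not yet been measured. It differs from compound 2 by isopropyl in place of methoxymethyl on a carbonyl carbon. Among the compounds with values here, the only measured step, a number 2 percentage points higher from compound 1 to compound 2 (within the scatter), also exchanges the group on the carbonyl carbon of the amide-type nitrogen in the ring, and that step stayed within the scatter. The change from compound 2 to compound 3 is a change of the same kind and of similar extent, so nothing beyond the scatter is expected in this assay; the step from compound 2 to compound 3 is estimated as a number 2 percentage points lower from compound 2 to compound 3 (within the scatter). Compound 3 is therefore expected to give about 40% in this assay, with a range from 25% to 55%.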

Compound 3, oral bioavailability: 87%
The estimate for compound 3 lay 47 percentage points below the measured number, and the stated range ends below it.
By their numbers in this assay, from the lowest: compounds 1 and 2 (each within the scatter of the next); then compound 3.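

In this assay the group on the carbonyl carbon proves to matter far more than the first pair suggested: isopropyl in place of methoxymethyl gives a number 45 percentage points higher from compound 2 to compound 3 (beyond the scatter) even though the two groups have the same count of heavy atoms and differ in that the entering group is all carbon, without the hydrogen-bond acceptor of the leaving one. The exchange of 4-(cyclopropylcarbonyl)-5-methylmorpholin-2-yl for 4-(isopropylcarbonyl)morpholin-2-yl gives a number 47 percentage points higher from compound 1 to compound 3 (beyond the scatter) in the same direction, so a change at this position can carry a large step, whereas compound 1 and compound 2 had stayed within the scatter of each other. Nothing shown here accounts for so large a step.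

The compounds shown do not separate the part played by cyclopropyl from that of the 5-methyl group, as the two differ together between compound 1 and compound 3. They also leave open how an ethyl, a tert-butyl or a dimethylamino group on the same carbonyl carbon would read in this assay, and so whether isopropyl stands alone or belongs to a wider set of groups.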